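Cyanomethyl removed from an oxygen, repeated on a second core

The source may report more compounds than this note shows. Statements on the series, on what has been measured and on what is new or still open speak of the compounds shown alone.

Compound 3 `CO[C@]1(c2cc(F)cc(Sc3ccc(/C(C)=N/OCC#N)cc3)c2)CCO[C@@H](C)C1` and compound 1 `CO[C@]1(c2cc(F)cc(Sc3ccc(/C(C)=N/O)cc3)c2)CCO[C@@H](C)C1` share one core and differ in a single place: hydrogen in place of cyanomethyl on an oxygen. In a functional assay (blood) for inhibition, with Homo sapiens as the target (on this read-out higher numbers stand for weaker inhibition and lower numbers for stronger inhibition), compound 3 gives 40 nM, and compound 1 gives 40 nM; the step of no change at the digits printed from compound 3 to compound 1 (within the scatter). Compound 2 `COC1(c2csc(Sc3ccc4c(c3)OCC/C4=N\OCC#N)c2)CCOCC1` is built on another core; how the two cores differ is not broken down here. In this assay compound 2 gives 60 nM, which lies within the scatter of both compound 1 and compound 3. Compound 4 `COC1(c2csc(Sc3ccc4c(c3)OCC/C4=N\O)c2)CCOCC1` has not yet been measured. It differs from compound 2 by hydrogen in place of cyanomethyl on an oxygen, the same change as that from compound 3 to compound 1, made at a place described in the same words. The expected step is no change at the digits printed from compound 2 to compound 4 (within the scatter). This expectation rests on the step of no change at the digits printed from compound 3 to compound 1 (within the scatter), which stayed within the scatter. Compound 4 is estimated at 60 nM, in a range from 30 nM to 120 nM.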

Compound 4, half-maximal inhibitory concentration: 40 nM
Estimate against measurement, compound 4: 1.5-fold (0.18 log units) above; the measured number falls inside the stated range.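

In this assay, hydrogen in place of cyanomethyl on the oxygen gives a 1.5-fold lower number from compound 2 to compound 4 (0.18 log units; within the scatter), and set beside the earlier step the change reads alike on the two cores: the same change on two cores in this assay, no change at the digits printed (within the scatter) from compound 3 to compound 1 and a 1.5-fold lower number (0.18 log units; within the scatter) from compound 2 to compound 4, 1.5-fold (0.18 log units) apart, within the scatter of two such steps. On these two cores, then, the step carried over from one core to the other, with the read-out staying within the scatter each time. Two pairs do not show that it would hold on a further core, and they do not say why removing cyanomethyl makes so little difference here.

The compounds shown leave open what other groups on this oxygen would do, such as methyl, a longer chain, or a chain ending in an amine or a carboxylic acid. They also leave open whether the two cores would still agree in any other read-out.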